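Lutropin receptor agonists: hydroxyphenyl to fluorophenyl

The compounds below may be only part of what the source reports. "The series", "measured", "known", "first", "only" and "open" are said of these compounds alone.

Measured compounds:
- compound 1 `CSc1nc(-c2cccc(O)c2)c2c(N)c(C(=O)NC(C)(C)C)sc2n1`: 1900 nM
- compound 2 `CCOC(=O)c1sc2nc(SC)nc(-c3cccc(OC)c3)c2c1N`: "not determined" (no result reported)
- compound 3 `COc1cccc(-c2nc(SC)nc3sc(C(=O)N(C)C(C)(C)C)c(N)c23)c1`: 800 nM

In a functional assay on HEK293 cells for agonist activity at lutropin-choriogonadotropic hormone receptor (Homo sapiens), read by cAMP accumulation (on this read-out lower numbers stand for an effect already at smaller amounts and higher numbers for an effect only at larger amounts of compound), compound 1 gives 1900 nM, the highest of the two numbers at hand. Among the compounds with values here, the nearest is compound 3, which in this assay gives 800 nM, a gap beyond the scatter; compound 3 also carries a different amide and a methoxy group, so no single step connects the two. For compound 2 no result is reported.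

Compound 4 `CSc1nc(-c2cccc(F)c2)c2c(N)c(C(=O)NC(C)(C)C)sc2n1` differs from compound 1 by fluoro in place of hydroxy on an aromatic carbon. Within the data shown here, no measured pair isolates this change. The expected step from compound 1 to compound 4 is a 1.3-fold higher number from compound 1 to compound 4 (0.12 log units; within the scatter), toward a somewhat higher number but not clearly beyond the scatter. Compound 4 is estimated at 2500 nM, range 800 nM to 8000 nM.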

Compound 4, half-maximal effective concentration: 1200 nM
Beside the measured number, compound 4's estimate is 2.1-fold (0.32 log units) above it; the measured number falls inside the stated range.
By their numbers in this assay, from the lowest: compounds 3, 4 and 1 (each within the scatter of the next, the first and the last beyond it).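

In this assay this first single-change pair gives a 1.6-fold lower number from compound 1 to compound 4 (0.20 log units; within the scatter), so 3-hydroxyphenyl and 3-fluorophenyl cannot be told apart at this position. A hydroxy group on this aromatic carbon is therefore not needed for activity in this range, since fluoro, with no hydrogen-bond donor or acceptor, serves in its place. No measurement on hand explains why the two read alike.

Still open, on these data alone, is whether an amine or a chloro group on the same carbon would also read alike. Also open, as far as these compounds go, is whether fluoro in place of hydroxy gives the same result with the amide of compound 3.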